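A larger group on the chain of a weak inhibitor

This account rests on a few compounds, and the source may have more. Where it says the series, first, only, none or still open, it means among the compounds named here.

Values so far in a functional assay on K562 cells (Homo sapiens) for inhibition (on this read-out higher numbers stand for weaker inhibition and lower numbers for stronger inhibition), are these
compound 1 `CC(C)CC(=O)OC1C(C(O)CO)OC2OC(C)(C)OC21` gives 1000000 nM
compound 2 `CC1(C)OC2OC(C(O)CO)C(OC(=O)CC(c3ccccc3)c3ccccc3)C2O1` gives 500000 nM
compound 3 `CC(=O)OC1C(C(O)CO)OC2OC(C)(C)OC21` gives 3800000 nM

Compound 3 has the highest number of the three, which makes it the weakest inhibitor in this small set. Compound 4 `CC(CC(=O)OC1C(C(O)CO)OC2OC(C)(C)OC21)c1ccccc1` differs from compound 3 in one place 1-phenylethyl in place of hydrogen on a saturated chain carbon bound to a carbonyl carbon and so gains one six-membered aromatic ring of carbon only.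

The closest measured change is at the same place, where hydrogen replaces isopropyl, and it gives a 3.8-fold higher number from compound 1 to compound 3 (0.58 log units; beyond the scatter) in this assay and is a modest step. Read in reverse, a larger group there lowers the number. Compound 2, which also has a larger group on that chain, stands at 500000 nM and is likewise lower than compound 3. A modest drop in this assay is therefore expected, though only these compounds support it. The expected step is a 5.4-fold lower number from compound 3 to compound 4 (0.73 log units; beyond the scatter) in this estimate. Compound 4 is estimated at 700000 nM with an expected range from 300000 nM to 1600000 nM in this assay.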

Compound 4, half-maximal inhibitory concentration: 500000 nM
For compound 4 the middle estimate is 1.4-fold (0.15 log units) above the measured one, within the range that was stated.
By their numbers in this assay, from the lowest: compounds 2, 4 and 1 (each within the scatter of the next); then compound 3.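

Adding 1-phenylethyl in place of hydrogen on a saturated chain carbon bound to a carbonyl carbon gives a 7.6-fold lower number from compound 3 to compound 4 (0.88 log units; beyond the scatter) in this assay, so a group carrying an aromatic ring can also lower the number at this place. Methyl in place of phenyl on the chain gives no change at the digits printed from compound 2 to compound 4 (within the scatter) and phenyl in place of methyl gives a 2.0-fold lower number from compound 1 to compound 4 (0.30 log units; within the scatter) on the other side. Both steps stay within the scatter, so exchanging phenyl and methyl at these chain carbons shows no measurable change in either pair. Nothing available here explains the drop from hydrogen to 1-phenylethyl. From the compounds shown here alone, whether an amine or a carboxylic acid on this chain would move the number remains open, as does the effect of a longer chain.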